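This account rests on a few compounds, and the source may have more. Where it says the series, first, only, none or still open, it means among the compounds named here.

Working notes on the series in an ADME assay on HepG2 cells (Homo sapiens) for cytotoxicity, read by CellTiter-Glo, with a stated time of 48 h; a higher number here means that more compound is tolerated, a lower number that less compound is tolerated. Compound 1 `C[S+]([O-])c1ccc(-c2nc3ccc(Cl)cc3nc2-c2ccc(Cl)cc2)cc1` gives 1580 nM. Compound 2 `COc1ccc2nc(NCCO)c(S(C)(=O)=O)nc2c1` gives 39800 nM. Compound 3 `COc1ccc2nc(S(C)(=O)=O)c(NCCO)nc2c1` reads > 100000 nM, a limit of the assay and not a number, and so sits at the limit of > 100000 nM in this assay, at which 1 of the 3 values shown sits. The other two compounds both return numbers under that limit.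

Compound 4 `COc1ccc2nc(S(C)(=O)=O)c(NCCC(C)C)nc2c1` keeps the core of compound 3 and changes only the end of the chain: isopropyl in place of hydroxy on a saturated chain carbon, two bonds along the chain from a nitrogen on an aromatic ring. This is isopropyl in place of hydroxy on a saturated chain carbon, two bonds along the chain from a nitrogen on an aromatic ring, or (2-hydroxyethyl)amino to isopentylamino when cut further out.

Within the data shown here, no measured pair isolates this change, so any expectation rests on thin ground. Compound 2 also carries the hydroxy group and still reads 39800 nM. Compound 1 has no hydroxy group, on a different core, and reads 1580 nM. On these two values, a move to less compound tolerated in this assay is expected, beyond the scatter, though a reading at the limit remains possible. The expected step of an at least 3.3-fold lower number from compound 3 to compound 4 (0.52 log units; beyond the scatter) is only an estimate, since its starting point is a limit. Compound 4 is estimated at 30000 nM, with an expected range of 8000 nM to 100000 nM.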

Compound 4, half-maximal cytotoxic concentration: 50100 nM
Compound 4: middle estimate off by 1.7-fold (0.22 log units), on the low side; low and high end bracket the measured number.
By their numbers in this assay, from the lowest: compound 1; then compounds 2 and 4 (each within the scatter of the next). At a limit, above all of these: compound 3.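

In this assay, isopropyl in place of hydroxy on a saturated chain carbon, two bonds along the chain from a nitrogen on an aromatic ring, now has its first direct reading, an at least 1.9-fold lower number from compound 3 to compound 4 (0.30 log units; that floor lies within the scatter). Among these compounds, earlier compounds offered no pair differing in one place, whereas here the isopentylamino chain returns a number under the limit on the same core on which the (2-hydroxyethyl)amino chain does not. Compound 3 remains a limit of the assay and not a number, so this step has only a floor and the full size of the change cannot be read: the limit of > 100000 nM in this assay, at which 1 of the 4 values shown sits.

The compounds shown leave open whether the move from hydroxy to isopropyl truly exceeds the scatter, and whether the same change gives a similar step on the core of compound 2. Also open, on these data alone, is how an amine, a carboxylic acid or a longer chain in place of hydroxy at this chain carbon would read, and so whether the reading follows the hydroxy group itself or the larger isopropyl group that enters.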